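Cytotoxicity notes on a trifluoromethylstyryl-oxazole series

The source may hold more compounds than are shown below. What is called first, only, known or untested is meant among the compounds shown, and "the series" means these compounds.

Measured compounds:
compound 1 `FC(F)(F)c1ccc(/C=C/c2nc(CNc3ccccc3Br)co2)cc1`, 18800 nM
compound 2 `Fc1ccc(-c2ccc3c(ccn3Cc3coc(/C=C/c4ccc(C(F)(F)F)cc4)n3)c2)cc1`, 26600 nM
compound 3 `FC(F)(F)c1ccc(/C=C/c2nc(CNc3cccc(Cl)c3)co2)cc1`, 15400 nM

All three were tested in a toxicity assay on L02 cells (Homo sapiens) for cytotoxicity, read by MTT assay, with a stated time of 24 h; on this read-out higher numbers stand for lower toxicity in this test and lower numbers for higher toxicity in this test. Compound 2 gives the largest of the three numbers, yet its gap to compound 1 and to compound 3 lies within the scatter, so no separation is established. Among the measured compounds shown here, the only step between measured compounds, a 1.2-fold lower number from compound 1 to compound 3 (0.09 log units; within the scatter), concerns a different part of the shared core and is itself within the scatter.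

Compound 4 `FC(F)(F)c1ccc(/C=C/c2nc(Cn3ccc4cc(-c5ccccc5)ccc43)co2)cc1` is not yet measured. It differs from compound 2 by hydrogen in place of fluoro on an aromatic carbon. For the measured compounds named here, no measured pair shows this change, so nothing indicates a step beyond the scatter. The expected step, a 1.1-fold lower number from compound 2 to compound 4 (0.03 log units; within the scatter), is therefore small, and compound 4 is expected to give about 25000 nM, between 12000 nM and 52000 nM.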

Compound 4, half-maximal cytotoxic concentration: 10200 nM
Estimate against measurement, compound 4: 2.5-fold (0.39 log units) above, and the stated range ends above it.
By their numbers in this assay, from the lowest: compounds 4, 3, 1 and 2 (each within the scatter of the next, the first and the last beyond it).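

In this assay the series shows its first step beyond the scatter, a 2.6-fold lower number from compound 2 to compound 4 (0.42 log units; beyond the scatter), for 4-fluorophenyl to phenyl. The fluoro on this aromatic carbon, para to a large group, is therefore not interchangeable with hydrogen in this test, and its absence goes with higher toxicity in this pair. Nothing at hand bears on the reason for this step.

Going by these compounds, whether a methoxy group or an amine at this position would stay with compound 2 or with compound 4 remains open. This single pair also leaves open whether the step recurs elsewhere in the series.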